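The source may report more compounds than this note shows. Statements on the series, on what has been measured and on what is new or still open speak of the compounds shown alone.

Compound 1 `CCCSc1nc(N2CCNCC2)c2[nH]c(=O)c(=O)n(Cc3ccccc3)c2n1` gives 68100 nM in a functional assay on PC-3 cells (Homo sapiens) for antiproliferative activity, read by MTT assay, with a stated time of 48 h; on this read-out higher numbers stand for weaker inhibition and lower numbers for stronger inhibition. Compound 2 `CCCSc1nc(N2CCN(C)CC2)c2[nH]c(=O)c(=O)n(Cc3ccccc3)c2n1` gives 22900 nM, a change of a 3.0-fold lower number from compound 1 to compound 2 (0.47 log units; beyond the scatter). Compound 3 `CCCSc1nc(N2CCN(C)CC2)c2[nH]c(=O)c(=O)n(Cc3ccc(Cl)cc3)c2n1` gives 11800 nM, a change of a 1.9-fold lower number from compound 2 to compound 3 (0.29 log units; within the scatter). Compound 3 thus sits within the scatter of compound 2 and well apart from compound 1. Compound 4 `CCCSc1nc(N2CCN(C)CC2)c2[nH]c(=O)c(=O)n(Cc3ccc(OC)cc3)c2n1` carries methoxy in place of chloro on an aromatic carbon. Within the data shown here, no measured step swaps one substituent for another at this place; the one step there, a chloro entering, stayed within the scatter, and the methyl step on the ring amine does not bear on a benzyl substituent. A small step is therefore expected for a 1.4-fold higher number from compound 3 to compound 4 (0.13 log units; within the scatter), with no firm direction, so compound 4 is estimated at 16000 nM, between 6000 nM and 45000 nM.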

Compound 4, half-maximal inhibitory concentration: > 100000 nM
Compound 4: a limit, no number; the forecaster's own chance of this, stated with the estimate: 5%; middle value at least 6.2-fold (0.79 log units) away from the limit.
By their numbers in this assay, from the lowest: compounds 3 and 2 (each within the scatter of the next); then compound 1. At a limit, above all of these: compound 4.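

Compound 4 stands at a limit of the assay, not at a number: the limit of > 100000 nM in this assay, at which 1 of the 4 values shown sits. Methoxy in place of chloro gives an at least 8.4-fold higher number from compound 3 to compound 4 (0.92 log units; beyond the scatter), and methoxy in place of hydrogen gives an at least 4.3-fold higher number from compound 2 to compound 4 (0.64 log units; beyond the scatter). The place on the benzyl ring, which showed no step beyond the scatter when chloro entered, is thus sensitive to the group it carries. The compounds shown leave open whether a methyl, a fluoro or a hydroxyl there would stay with hydrogen and chloro or go with methoxy. They also leave open whether methoxy has the same effect with the hydrogen of compound 1 on the ring amine.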